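Ethoxy series, cytotoxicity: adding a third ring methyl

The compounds below may be only part of what the source reports. "The series", "measured", "known", "first", "only" and "open" are said of these compounds alone.

Measured so far:
compound 1, `CCOc1cccc2c1NC(C)(C)C=C2`, 200 uM
compound 2, `CCOc1c(C)cc2c(c1C)C=CC(C)(C)N2`, 182 uM

In a functional assay on HT-22 cells (Mus musculus) for cytotoxicity (on this read-out lower numbers stand for higher toxicity in this test and higher numbers for lower toxicity in this test), compound 1 gives 200 uM and compound 2 gives 182 uM. For the measured compounds named here, the two numbers lie within the scatter of one another, so on this read-out compound 2 is not separated from compound 1; both sit in the same high-concentration region of this assay, and there is no step between two measured compounds that could be read as a trend.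

The next compound, compound 3, `CCOc1c(C)c(C)c2c(c1C)C=CC(C)(C)N2`, differs from compound 2 by a single change: methyl in place of hydrogen on an aromatic carbon. Going by the values given here, nothing measured so far tells how such a change acts; the only comparison, compound 1 against compound 2, carries several changes at once and stays within the scatter.

The step from compound 2 to compound 3 is therefore expected to be a 1.1-fold lower number from compound 2 to compound 3 (0.04 log units; within the scatter), which is nothing beyond the scatter in either direction. Compound 3 is expected at about 165 uM, with a range from 80 uM to 330 uM.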

Compound 3, half-maximal toxic concentration: 123 uM
Compound 3: the middle estimate sits 1.3-fold (0.13 log units) above what was measured; measured number inside the range.
By their numbers in this assay, from the lowest: compounds 3, 2 and 1 (each within the scatter of the next).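

Working notes, position and change: in this assay, methyl in place of hydrogen on this aromatic carbon gives a 1.5-fold lower number from compound 2 to compound 3 (0.17 log units; within the scatter) and so provides the first comparison in the series that differs in one place. The carbon sits ortho to a fused ring, ortho to a methyl group and para to a methyl group, and a methyl placed there does not separate compound 3 from compound 2 on this read-out, so the added heavy atom leaves no effect that can be told from the scatter. No further data bear on this step, and its origin stays unexplained.

Open points: this single replacement shows only how methyl compares with hydrogen at this one aromatic carbon, and says nothing about whether the same replacement at another ring carbon would read alike. Whether an amine, a carboxylic acid or a longer chain such as propyl on this carbon would give a step beyond the scatter in this assay remains an open question for the series.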